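This account rests on a few compounds, and the source may have more. Where it says the series, first, only, none or still open, it means among the compounds named here.

In a functional assay on isolated protein for agonist activity at Glucose-dependent insulinotropic receptor (Rattus norvegicus), read by HTRF and cAMP accumulation (on this read-out lower numbers stand for smaller maximal responses and higher numbers for larger maximal responses), compound 2 `CC(C)(C)OC(=O)N1CCC(O[C@H]2CC[C@H](Oc3ccc(S(C)(=O)=O)cc3)CC2)CC1` gives 120%, the second highest of the three numbers measured. Its mirror image compound 1 `CC(C)(C)OC(=O)N1CCC(O[C@H]2CC[C@@H](Oc3ccc(S(C)(=O)=O)cc3)CC2)CC1` gives 121%, and compound 3 `CC(C)(C)OC(=O)N1CCC(O[C@H]2CC[C@H](Oc3ccc(S(C)(=O)=O)c(F)c3)CC2)CC1` gives 109%. The step of a number 1 percentage points lower from compound 1 to compound 2 (within the scatter) lies within the scatter, as would fit (the fact that compounds 1 and 2 differ only in the configuration as drawn). Within the data shown here, the step of a number 11 percentage points lower from compound 2 to compound 3 (beyond the scatter) is the one measured change on the aromatic ring of the 4-(methylsulfonyl)phenyl group. Compound 4 `CC(C)(C)OC(=O)N1CCC(O[C@H]2CC[C@H](Oc3ccc(S(C)(=O)=O)cn3)CC2)CC1` alters that same ring differently: 5-(methylsulfonyl)pyridin-2-yl in place of 4-(methylsulfonyl)phenyl on an oxygen on a saturated carbon. Among the measured compounds shown here, no measured step introduces a ring nitrogen, so the fluoro step is the nearest guide and points to a modest drop, or none beyond the scatter, in this assay. Compound 4 is therefore expected to give 112%, within 96% to 128%. This estimate corresponds to an expected step of a number 8 percentage points lower from compound 2 to compound 4 (within the scatter).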

Compound 4, largest response reached (Emax), in percent of the reference or control that the assay uses: 108%
For compound 4 the middle estimate is 4 percentage points above the measured one; the measured number falls inside the stated range.
By their numbers in this assay, from the lowest: compounds 4 and 3 (each within the scatter of the next); then compounds 2 and 1 (each within the scatter of the next).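

In this assay, the change to 5-(methylsulfonyl)pyridin-2-yl on the oxygen gives a number 12 percentage points lower from compound 2 to compound 4 (beyond the scatter), so a ring nitrogen, like the fluoro group, moves the maximal response beyond the scatter. Compound 4 at 108% and compound 3 at 109% stand within the scatter of each other, so these two different edits of the ring end at a similar level. Nothing measured here accounts for this step. Still open, from the compounds shown here alone, is whether a carboxylic acid in place of the methylsulfonyl group would keep the response, and whether the pyridine ring behaves alike in the configuration of compound 1.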